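The source may hold more compounds than are shown below. What is called first, only, known or untested is meant among the compounds shown, and "the series" means these compounds.

Measured so far:
Compound 1, `C[C@@H]1CN(c2nccc3[nH]c(-c4ccc(F)c(F)c4)nc23)C[C@H](C)N1`, gives 190000 nM in a physicochemical assay for solubility, read by HPLC, using the shake flask method, in phosphate buffer, with a stated time of 20 h, at pH 6.5; on this read-out lower numbers stand for lower solubility and higher numbers for higher solubility.
Compound 2, `C[C@@H]1CN(c2nccc3[nH]c(-c4ccc(F)c(F)c4)nc23)C[C@H](C)N1C`, gives 50000 nM in this assay.
Compound 3, `CN1CCN(C2CCN(c3nccc4[nH]c(-c5ccc(F)c(C(F)(F)F)c5)nc34)CC2)CC1`, gives 195000 nM in this assay.

One single-point change is measured. From compound 2 to compound 1 the change is hydrogen in place of methyl on an amine nitrogen in a ring and the step is a 3.8-fold higher number from compound 2 to compound 1 (0.58 log units; beyond the scatter). Compound 3 gives a higher number than compound 2, while compound 3 and compound 1 lie within the scatter of each other. The difference between the core of compound 3 and the core of compound 2 is not broken down here.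

Compound 4, `Fc1ccc(-c2nc3c(N4CCC(N5CCNCC5)CC4)nccc3[nH]2)cc1C(F)(F)F`, is not yet measured in this assay. It differs from compound 3 by hydrogen in place of methyl on an amine nitrogen in a ring. Within the data shown here, this is the same kind of change as the one from compound 2 to compound 1, not the same: in compound 2 the amine nitrogen sits next to two ring atoms that each bear a methyl group (1 heavy atom), whereas in compound 3 no such groups are named around the place.

For compound 4 the step in this assay is expected to be a 2.1-fold higher number from compound 3 to compound 4 (0.31 log units; beyond the scatter), resting on the step of a 3.8-fold higher number from compound 2 to compound 1 (0.58 log units; beyond the scatter) and on the starting value of compound 3, 195000 nM, which is already the highest of the three. Compound 4 is therefore estimated at 400000 nM, with a range from 150000 nM to 1000000 nM.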

Compound 4, solubility: 200000 nM
Compound 4: middle estimate off by 2.0-fold (0.30 log units), on the high side; the range from low to high includes it.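

In this assay, hydrogen in place of methyl on an amine nitrogen in a ring gives a 3.8-fold higher number from compound 2 to compound 1 (0.58 log units; beyond the scatter) on one core and a 1.0-fold higher number from compound 3 to compound 4 (0.01 log units; within the scatter) on the other, so the size of the first step does not carry over to the second pair. This rests on a single pair for each core, and the two pairs also differ in what surrounds the amine nitrogen, so the data do not show whether the core or those surroundings set the size of the step, nor whether either step would hold for other compounds in the series. Nothing available here bears on why the two steps differ.

Still open, on these data alone, is how other groups on this amine nitrogen, such as ethyl, a longer chain or an acetyl group, would read on the two cores. Also open, as far as these compounds go, is whether a carboxylic acid on that nitrogen would give the same reading on both cores in this assay or a different one on each.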